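This account rests on a few compounds, and the source may have more. Where it says the series, first, only, none or still open, it means among the compounds named here.

Of the compounds shown here, three have so far been tested in a functional assay on L1210 cells (Mus musculus) for inhibition, read by cell counting, with a stated time of 2 days; on this read-out lower numbers stand for stronger inhibition and higher numbers for weaker inhibition. Compound 1 `COc1ccc(-c2nn3cc(-c4cccc(N)c4)nc3s2)cc1OC` gives 16000 nM in this assay. Compound 2 `C=C(Br)C(=O)Nc1cccc(-c2cn3c(-c4ccc(OC)cc4)csc3n2)c1` gives 200 nM. Compound 3 `C=C(Br)C(=O)Nc1cccc(-c2cn3nc(Cc4cccc(OC)c4)sc3n2)c1` gives 2000 nM, which is the second highest of the three numbers: compound 1 sits above it and compound 2 below it, and both gaps lie beyond the usual scatter of this assay.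

Compound 4 `C=C(Br)C(=O)Nc1cccc(-c2cn3nc(-c4ccc(Cl)cc4)sc3n2)c1` has not been measured yet. It differs from compound 3 in one place: 4-chlorophenyl in place of 3-methoxybenzyl on an aromatic carbon. Within the data shown here, no measured pair shows exactly this change, so its effect is not known from the data. Compound 2 and compound 3 differ in more than one place, so their gap in this assay cannot be assigned to this change alone, yet compound 2 shows that a lower number is reachable within this family. On balance a step from compound 3 to compound 4 of a 2.5-fold lower number from compound 3 to compound 4 (0.40 log units; beyond the scatter) is expected in this assay, tending toward a lower number. Compound 4 is therefore estimated at 800 nM, within a range from 200 nM to 3000 nM.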

Compound 4, half-maximal inhibitory concentration: 1400 nM
The estimate for compound 4 lay 1.8-fold (0.24 log units) below the measured number; measured number inside the range.
By their numbers in this assay, from the lowest: compound 2; then compounds 4 and 3 (each within the scatter of the next); then compound 1.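

In this assay, putting 4-chlorophenyl in place of 3-methoxybenzyl on this aromatic carbon gives a 1.4-fold lower number from compound 3 to compound 4 (0.15 log units; within the scatter), so the two compounds cannot be told apart on this read-out. Among these compounds, this is the first direct view of this position: the entering group has fewer heavy atoms, carries chlorine instead of oxygen and has no hydrogen-bond acceptor, yet the number does not move beyond the scatter. No separate measurement is available to explain this result.

Both groups seen here at this position contain a six-membered aromatic ring of carbon only, so one swap says little about the position as a whole. As far as these compounds go, whether an amine, a carboxylic acid or a plain alkyl chain on this carbon would shift the number remains open.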